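Compound 2 to compound 3: one side-chain ring exchanged

The source may hold more compounds than are shown below. What is called first, only, known or untested is meant among the compounds shown, and "the series" means these compounds.

Compound 1 `COc1cc2c(Nc3ccc(C#N)cc3)ncnc2cc1OCCCN1CCc2ccccc2C1`: > 100000 nM, a limit
Compound 2 `COc1cc2c(Nc3ccc(C#N)cc3)ncnc2cc1OCCCN1CCC(N(C)C)CC1`: 33600 nM

Both compounds were tested in a functional assay on HepG2 cells (Homo sapiens) for antiproliferative activity, read by MTT assay, with a stated time of 72 h; on this read-out lower numbers stand for stronger inhibition and higher numbers for weaker inhibition. For the measured compounds named here, compound 2 holds the only true number, as compound 1 reached only the limit of the test. Compound 3 `CCN1CCN(CCCOc2cc3ncnc(Nc4ccc(C#N)cc4)c3cc2OC)CC1` differs from compound 2 in one place: 4-ethylpiperazin-1-yl in place of 4-(dimethylamino)piperidin-1-yl on a saturated chain carbon, three bonds along the chain from an oxygen on an aromatic ring. Going by the values given here, the one measured step at this place is an at least 2.9-fold lower number from compound 1 to compound 2 (0.47 log units; beyond the scatter). It starts from a limit and involves a different ring, so it gives only a loose guide. No step beyond the scatter is therefore expected, and the estimated change is a 1.1-fold lower number from compound 2 to compound 3 (0.05 log units; within the scatter). Compound 3 is expected at 30000 nM, with an estimated range of 10000 nM to 90000 nM.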

Compound 3, half-maximal inhibitory concentration: 9580 nM
The estimate for compound 3 lay 3.1-fold (0.50 log units) above the measured number, outside the stated range (below it).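

In this assay, a true number at both ends now shows that the ring at this position can move the read-out beyond the scatter: 4-ethylpiperazin-1-yl in place of 4-(dimethylamino)piperidin-1-yl gives a 3.5-fold lower number from compound 2 to compound 3 (0.54 log units; beyond the scatter). Replacing 1,2,3,4-tetrahydroisoquinolin-2-yl gives an at least 10-fold lower number from compound 1 to compound 3 (1.01 log units; beyond the scatter), making compound 3 the most potent of the three. Compound 1 stands at a limit, so that second step has no exact size: the limit of > 100000 nM in this assay, at which 1 of the 3 values shown sits.

As far as these compounds go, it remains open whether the ethyl group or the piperazine ring carries the change. A 4-methylpiperazin-1-yl group, a morpholine ring or a longer chain could help separate these.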